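Adding a Second Chloro to a Benzyl Purine

The compounds below may be only part of what the source reports. "The series", "measured", "known", "first", "only" and "open" are said of these compounds alone.

Compound 1: `ClCc1ccc(Cn2cnc3c(Cl)ncnc32)cc1` — "not determined" (no result reported)
Compound 2: `ClCc1ccc(Cn2cnc3nc(Cl)nc(Cl)c32)cc1` — > 100000 nM

Two compounds share the benzyl chloride arm, and only one of them has a read-out. In a functional assay on HT-29 cells (Homo sapiens) for cytotoxicity, read by sulforhodamine B assay, with a stated time of 48 h (on this read-out lower numbers stand for stronger inhibition of growth and higher numbers for weaker inhibition of growth), compound 1 gives "not determined" (no result reported), so no number marks where it stands. Among the measured compounds shown here, for compound 2 the result is only a limit, > 100000 nM, meaning the assay reached its upper bound without seeing total growth inhibition; this is the one limit among the values shown, (the limit of > 100000 nM in this assay, at which 1 of the 2 values shown sits). Compound 3, `ClCc1ccc(Cn2cnc3c(Cl)nc(Cl)nc32)cc1`, has not been tested. It differs from compound 1 by chloro in place of hydrogen on an aromatic carbon. For the measured compounds named here, with no number for compound 1, no measured step can be drawn, and the direction of the change in this assay cannot be read from the data. Compound 3 is therefore estimated cautiously at 40000 nM, with an expected range from 5000 nM to 100000 nM.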

Compound 3, concentration for total growth inhibition: > 100000 nM
Compound 3: no number, only a limit (the forecaster's own chance of this, stated with the estimate: 50%); middle value at least 2.5-fold (0.39 log units) away from the limit.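

No step can be read from compound 1 to compound 3: compound 1 has no number, and compound 3 gives only a limit. The compounds shown leave open how chloro in place of hydrogen changes the result in this assay, with most values at one limit: the limit of > 100000 nM in this assay, at which 2 of the 3 values shown sit.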